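Pentafluorophenoxy in place of 2-nitrophenoxy on the ketone side

A few compounds are considered here, and "the series" means these few. Any claim that something is new, unique, unknown or untested is made for them only; others in the source may bear on it.

Measured compounds in a functional assay on Jurkat cells (Homo sapiens); a lower number here means a stronger inhibitor, a higher number a weaker inhibitor:
compound 1, `CC(C)[C@H](NC(=O)COc1cccc2ccccc12)C(=O)N[C@@H](CC(=O)O)C(=O)COc1cc(C(F)(F)F)cc(C(F)(F)F)c1`, gives > 100000 nM, which is a limit of the assay.
compound 2, `CC(C)[C@H](NC(=O)COc1cccc2ccccc12)C(=O)N[C@@H](CC(=O)O)C(=O)COc1ccc(Oc2ccccc2)cc1`, gives 12700 nM.
compound 3, `CC(C)[C@H](NC(=O)COc1cccc2ccccc12)C(=O)N[C@@H](CC(=O)O)C(=O)COc1ccccc1[N+](=O)[O-]`, gives > 100000 nM, which is a limit of the assay.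

Compound 3 thus sits at the limit of > 100000 nM in this assay, at which 2 of the 3 values shown sit, and no number is known for it, only this limit. Among the compounds with values here, of the three measured compounds, compound 2 is the only one with a number in this assay, and it lies far from the limit. No step between measured compounds that differ in one place is available, so nothing in the shown data ties one change in the aryloxy group to a change in the read-out.

Compound 4, `CC(C)[C@H](NC(=O)COc1cccc2ccccc12)C(=O)N[C@@H](CC(=O)O)C(=O)COc1c(F)c(F)c(F)c(F)c1F`, is not yet measured. 2,3,4,5,6-pentafluorophenyl in place of 2-nitrophenyl on an oxygen on a saturated carbon

The expectation for compound 4 is a step toward stronger inhibition, an at least 5.0-fold lower number from compound 3 to compound 4 (0.69 log units; beyond the scatter), leading out of the region of the limit, since compound 2 with its phenoxyphenoxy group shows that a number within reach of this assay is possible in the series; the expected value for compound 4 is 20000 nM, with a range from 3000 nM to 100000 nM.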

Compound 4, half-maximal inhibitory concentration: 3050 nM
Compound 4: the middle estimate sits 6.6-fold (0.82 log units) above what was measured; the measured number falls inside the stated range.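

In this assay, 2,3,4,5,6-pentafluorophenyl in place of 2-nitrophenyl on the oxygen gives an at least 32-fold lower number from compound 3 to compound 4 (1.51 log units; beyond the scatter), the first size attached to a change at this position, with the rest of the structure held constant. From the compounds shown here alone, compound 3 gives > 100000 nM, which is a limit and not a number, so the step is a bound and its true size remains unknown: the limit of > 100000 nM in this assay, at which 2 of the 4 values shown sit. At this position, the aryl group alone is enough to move the read-out to a measured number, as compound 4 gives 3050 nM.

The compounds shown do not separate the loss of the nitro group from the entry of the five fluorines. A plain phenyl or a phenyl carrying a single fluorine on this oxygen would be needed to tell these two contributions apart.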